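This account rests on a few compounds, and the source may have more. Where it says the series, first, only, none or still open, it means among the compounds named here.

Measured so far:
- compound 1 `COc1cc(-c2cc(/C=C/C(=O)c3ccc(Cl)c(Cl)c3)[nH]n2)cc(OC)c1OC` — 1330 nM
- compound 2 `COc1ccc(-c2cc(/C=C/C(=O)c3ccc(N)cc3)[nH]n2)cc1OC` — 1650 nM
- compound 3 `COc1ccc(-c2cc(/C=C/C(=O)c3ccc(N)cc3)[nH]n2)cc1` — 1210 nM

All three numbers come from a functional assay on NCI-H522 cells (Homo sapiens) for inhibition, read by sulforhodamine B assay, with a stated time of 48 h; on this read-out higher numbers stand for weaker inhibition of growth and lower numbers for stronger inhibition of growth. Compound 1 lies within the scatter of both compound 2 and compound 3, so the three are indistinguishable on this read-out.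

Going by the values given here, the only single-point step among them runs a 1.4-fold lower number from compound 2 to compound 3 (0.13 log units; within the scatter), and it touches the aryl ring on the pyrazole side of the shared core, not the carbonyl side.

Compound 4 `COc1ccc(C(=O)/C=C/c2cc(-c3cc(OC)c(OC)c(OC)c3)n[nH]2)cc1OC` differs from compound 1 as follows: 3,4-dimethoxyphenyl in place of 3,4-dichlorophenyl on a carbonyl carbon. Among the compounds with values here, no measured pair changes the group on the carbonyl carbon in isolation; compounds 2 and 3 carry a different group there than compound 1 and still fall within its scatter, and the one measured step is itself within the scatter. Nothing in the series therefore points to a shift in either direction, and the step from compound 1 to compound 4 is expected to stay within the scatter, with a 1.0-fold lower number from compound 1 to compound 4 (0.01 log units; within the scatter).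

For compound 4 the estimate in this assay is 1300 nM, with a likely range from 500 nM to 3500 nM.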

Compound 4, concentration for 50% growth inhibition: 180 nM
Estimate against measurement, compound 4: 7.2-fold (0.86 log units) above, and the stated range ends above it.
By their numbers in this assay, from the lowest: compound 4; then compounds 3, 1 and 2 (each within the scatter of the next).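

In this assay, the group on a carbonyl carbon proves to be a position where a single change registers: 3,4-dimethoxyphenyl in place of 3,4-dichlorophenyl gives a 7.4-fold lower number from compound 1 to compound 4 (0.87 log units; beyond the scatter), while the rest of the structure stays the same. Going by these compounds alone, the only earlier step, a 1.4-fold lower number from compound 2 to compound 3 (0.13 log units; within the scatter), involved a methoxy group on the other side of the shared core, so this is the first step to show a real difference. The change replaces a group with no hydrogen-bond acceptors by one with two and swaps two chlorine atoms for two methoxy groups, but no measurement available here explains the gain.

Within the data shown here, the single step cannot separate the loss of the chlorine atoms from the gain of the methoxy groups, nor show whether both methoxy groups are needed. As far as these compounds go, it also remains open whether a phenyl group carrying one methoxy group, an ethoxy group or a hydroxyl group on this carbonyl carbon would keep the lower number, and whether the aminophenyl group of compound 3 would do so on the core of compound 1.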